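Double-Bond Geometry in a Thromboxane Synthase Inhibitor Series

The compounds below may be only part of what the source reports. "The series", "measured", "known", "first", "only" and "open" are said of these compounds alone.

Compound 1 `O=C(O)CCc1cc(-c2cccnc2)cc2c1CCC(NS(=O)(=O)c1ccc(Cl)cc1)C2` was tested in an assay on blood with Thromboxane-A synthase (Homo sapiens) as the target (a higher number here means a weaker inhibitor, a lower number a stronger inhibitor), where compound 1 gives only a limit of > 5000 nM. Compound 2 `O=C(O)CCc1cc(Cc2cccnc2)cc2c1CCC(NS(=O)(=O)c1ccc(Cl)cc1)C2` differs by carrying (pyridin-3-yl)methyl in place of pyridin-3-yl on an aromatic carbon, and in this assay compound 2 gives 1100 nM; the step is an at least 4.5-fold lower number from compound 1 to compound 2 (0.65 log units; beyond the scatter). Compound 3 `O=C(O)CCC/C=C/c1cc(Cc2cccnc2)cc2c1CCC(NS(=O)(=O)c1ccc(Cl)cc1)C2` carries 5-carboxypent-1-en-1-yl in place of 2-carboxyethyl on an aromatic carbon, and in this assay compound 3 again gives only a limit of > 5000 nM. That step is an at least 4.5-fold higher number from compound 2 to compound 3 (0.65 log units; beyond the scatter). As far as these compounds go, compound 3 therefore stands at the weak end of what has been measured, sitting at the limit of > 5000 nM in this assay, at which 2 of the 3 values shown sit, so its true value is unknown beyond the limit.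

Compound 4 `O=C(O)CCC/C=C\c1cc(Cc2cccnc2)cc2c1CCC(NS(=O)(=O)c1ccc(Cl)cc1)C2` is the next step. It differs from compound 3 as follows: the two compounds have the same atoms and bonds; at least one stereo element is drawn with a configuration in one of them and without one in the other: 1 of 2 stereo elements differ; a double bond is drawn E in compound 3 and Z in compound 4. Neither measured step touched double-bond geometry; both changed the identity of a group, so neither bears directly on this change, and no shift beyond the scatter is expected in this assay. Compound 4 is thus expected to remain near the limit, estimated at 6000 nM with a range of 2000 nM to 20000 nM, which means an expected step that the limit leaves unreadable from compound 3 to compound 4.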

Compound 4, half-maximal inhibitory concentration: 4200 nM
Beside the measured number, compound 4's estimate is 1.4-fold (0.15 log units) above it; the measured number falls inside the stated range.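

Compound 4 gives the 5-carboxypent-1-en-1-yl chain its first measured number in this assay rather than a limit, so the swap from 2-carboxyethyl on this aromatic carbon now has a size: a 3.8-fold higher number from compound 2 to compound 4 (0.58 log units; beyond the scatter). The change in double-bond geometry itself amounts to an at least 1.1-fold lower number from compound 3 to compound 4 (0.07 log units; that floor lies within the scatter), and with that floor inside the usual scatter, no order can be set between the E and Z forms. Compound 3 remains a limit of the assay, and for that reason the true size of the geometry step stays unknown: the limit of > 5000 nM in this assay, at which 2 of the 4 values shown sit.

Still open, as far as these compounds go, is whether the loss relative to the 2-carboxyethyl compound follows from the added chain length or from the double bond, a question that the saturated 5-carboxypentyl chain on the same core would separate. From the compounds shown here alone, it is also open whether a tetrazole in place of the carboxylic acid at the end of the Z chain would shift the number in this assay at all.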